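The source may report more compounds than this note shows. Statements on the series, on what has been measured and on what is new or still open speak of the compounds shown alone.

Series notes. All three measured compounds carry the same sulfonamide-bearing core; they differ only in the aryl group on the sulfonamide nitrogen. In an ADME assay on the whole organism for pharmacokinetics, with Homo sapiens as the target (a lower number here means that a smaller share of the oral dose reaches the circulation, a higher number that a larger share of the oral dose reaches the circulation), compound 1 `O=S(=O)(Nc1ccccn1)c1ccc2nc(-c3ccccc3)c(-c3ccccc3)nc2c1` gives 100%. Compound 2 `O=[N+]([O-])c1ccc(NS(=O)(=O)c2ccc3nc(-c4ccccc4)c(-c4ccccc4)nc3c2)cc1` gives 87.6% in this assay, and compound 3 `O=C(O)c1ccccc1NS(=O)(=O)c1ccc2nc(-c3ccccc3)c(-c3ccccc3)nc2c1` gives 83.6%. Compound 3 thus holds the lowest of the three numbers: its gap to compound 2 stays within the scatter, while a number 16.4 percentage points lower from compound 1 to compound 3 (beyond the scatter) lies beyond it, as does a number 12.4 percentage points lower from compound 1 to compound 2 (beyond the scatter).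

Compound 4 `O=S(=O)(Nc1ccccc1)c1ccc2nc(-c3ccccc3)c(-c3ccccc3)nc2c1` is not yet measured. The change from compound 3 is hydrogen in place of carboxy on an aromatic carbon, the carboxy sitting ortho to a large group in compound 3 and simply absent in compound 4. For the measured compounds named here, no measured step removes a carboxy from an otherwise unchanged aryl group, so the expectation rests on neighbours: a number 4 percentage points lower from compound 2 to compound 3 (within the scatter) shows that swapping one substituted phenyl for another moves this assay little, whereas compound 1, whose pyridin-2-yl is closest in size to a bare phenyl, stands highest. Compound 4 is therefore expected to lie between compound 3 and compound 1, with a number 8.4 percentage points higher from compound 3 to compound 4 (within the scatter) as an upward step of modest size. The estimate for compound 4 in this assay is 92%, with a range from 80% to 100%.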

Compound 4, oral bioavailability: 100%
Compound 4: middle estimate off by 8 percentage points, on the low side; low and high end bracket the measured number.
By their numbers in this assay, from the lowest: compounds 3 and 2 (each within the scatter of the next); then compounds 1 and 4 (each within the scatter of the next).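

The carboxy and nitro groups now each have a step to the bare phenyl. In this assay, removing the carboxy gives a number 16.4 percentage points higher from compound 3 to compound 4 (beyond the scatter), and hydrogen in place of nitro gives a number 12.4 percentage points higher from compound 2 to compound 4 (beyond the scatter), so among these compounds each of the two substituted phenyl groups stands apart from the unsubstituted one, although the two do not stand apart from each other. Phenyl in place of pyridin-2-yl gives no change at the digits printed from compound 1 to compound 4 (within the scatter), so at this position the exchange between these two unsubstituted aryl groups leaves the oral bioavailability read-out unchanged, which the earlier compounds could not show. No measurement available here accounts for these steps.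

The compounds shown leave open whether the lower numbers belong to carboxy and nitro in particular or would also appear with another substituent on the phenyl, such as an amine, a methoxy group or a fluorine atom, and the two steps cannot separate the identity of the group from its place on the ring. They also leave open how a non-aromatic group on the sulfonamide nitrogen, such as a longer alkyl chain, would compare with phenyl and pyridin-2-yl.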